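Methoxy count on the aryl ring and cytotoxicity

This account rests on a few compounds, and the source may have more. Where it says the series, first, only, none or still open, it means among the compounds named here.

Values in a functional assay on A549 cells (Homo sapiens) for cytotoxicity, read by MTT assay, with a stated time of 48 h (a higher number here means a weaker inhibitor, a lower number a stronger inhibitor), so far:
compound 1 `COc1ccc(-c2cc(C(=O)Nc3nc4ccc(Cl)cc4s3)nc3cc(-c4ccccc4)nn23)cc1`: 3090 nM
compound 2 `COc1ccc(-c2cc(C(=O)Nc3nc4ccc(Cl)cc4s3)nc3cc(-c4ccccc4)nn23)cc1OC`: 6160 nM
compound 3 `COc1ccc(-c2cc(C(=O)Nc3nc4ccc(F)cc4s3)nc3cc(-c4ccccc4)nn23)cc1OC`: 6910 nM

From compound 1 to compound 2 the change is methoxy in place of hydrogen on an aromatic carbon and it gave a 2.0-fold higher number from compound 1 to compound 2 (0.30 log units; within the scatter). The next step, a 1.1-fold higher number from compound 2 to compound 3 (0.05 log units; within the scatter), is also small. How the core of compound 1 differs from that of compound 3 is not broken down here.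

Compound 4 `COc1cc(-c2cc(C(=O)Nc3nc4ccc(F)cc4s3)nc3cc(-c4ccccc4)nn23)cc(OC)c1OC` is not yet measured. It differs from compound 3 by methoxy in place of hydrogen on an aromatic carbon. This is the same kind of change as from compound 1 to compound 2, not the same one: in compound 4 the place is also meta to a methoxy group, which it was not in compound 2. The step from compound 3 to compound 4 is expected to be a 1.4-fold higher number from compound 3 to compound 4 (0.16 log units; within the scatter), a little larger than but of the same direction as a 2.0-fold higher number from compound 1 to compound 2 (0.30 log units; within the scatter), on which the expectation rests. For compound 4 the estimate in this assay is 10000 nM, expected to lie between 4500 nM and 25000 nM.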

Compound 4, half-maximal inhibitory concentration: 22400 nM
Compound 4: middle estimate off by 2.2-fold (0.35 log units), on the low side; measured number inside the range.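

In this assay the step to the 3,4,5-trimethoxyphenyl ring is a 3.2-fold higher number from compound 3 to compound 4 (0.51 log units; beyond the scatter). Set beside the earlier methoxy step, the change points the same way on both cores, and the two sizes do not separate: the same change on two cores in this assay, a 2.0-fold higher number (0.30 log units; within the scatter) from compound 1 to compound 2 and a 3.2-fold higher number (0.51 log units; beyond the scatter) from compound 3 to compound 4, 1.6-fold (0.21 log units) apart, within the scatter of two such steps. Two steps, one on a chloro core and one on a fluoro core, do not show that the change carries to further cores, and they do not show how much depends on the place, which in the later step is also meta to a methoxy group.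

The compounds shown leave open whether a hydroxy group, an amine or a longer chain such as ethoxy in place of a methoxy group follows the same direction.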